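Lengthening the Side Chain of Compound 2

The source may report more compounds than this note shows. Statements on the series, on what has been measured and on what is new or still open speak of the compounds shown alone.

Measured so far (a functional assay on HCT-116 cells (Homo sapiens) for antiproliferative activity, read by MTT assay, with a stated time of 48 h; on this read-out higher numbers stand for weaker inhibition and lower numbers for stronger inhibition):
- compound 1 `CCCC(CCO)n1cnc2c(Cl)nc(F)nc21` gives 16500 nM
- compound 2 `CCCC(CCO)n1cnc2c(Cl)ncnc21` gives > 50000 nM as a limit
- compound 3 `CCCCCCC(CCO)n1cnc2c(N)nc(Cl)nc21` gives > 50000 nM as a limit

Compound 2 has no exact number, only a limit, and it sits at the limit of > 50000 nM in this assay, at which 2 of the 3 values shown sit. Compound 4 `CCCCCCCCCCC(CCO)n1cnc2c(Cl)ncnc21` differs from it by one change (heptyl in place of hydrogen on a saturated chain carbon, four bonds along the chain from an aromatic nitrogen), so heptyl replaces hydrogen on a saturated chain carbon, four bonds along the chain from an aromatic nitrogen.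

Among the compounds with values here, the one measured step (an at least 3.0-fold higher number from compound 1 to compound 2 (0.48 log units; beyond the scatter)) lies on the core and not on the chain, so it offers only a sense of size. Compound 3 has a longer chain than compound 2 and a different core pattern, yet it also remains at the limit. A modest step towards a lower number, meaning stronger inhibition, is therefore expected, though compound 4 may well stay at the limit. The expected change is uncertain (an at least 2.5-fold lower number from compound 2 to compound 4 (0.39 log units; beyond the scatter)). For compound 4 the estimated value is 20000 nM (range 6000 nM to 50000 nM).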

Compound 4, half-maximal inhibitory concentration: 4930 nM
The estimate for compound 4 lay 4.1-fold (0.61 log units) above the measured number, and the stated range ends above it.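

In this assay, placing heptyl on a saturated chain carbon, four bonds along the chain from an aromatic nitrogen, gives an at least 10-fold lower number from compound 2 to compound 4 (1.00 log units; beyond the scatter). This shows that the side chain, and not only the core, can move the read-out, and that a change at this position can bring a compound from the limit to an exact number. The step is a minimum and not an exact size, because compound 2 has only a limit: the limit of > 50000 nM in this assay, at which 2 of the 4 values shown sit.

As far as these compounds go, with a single chain length measured on this core, it remains open whether the number keeps falling as the chain grows, or whether a shorter butyl chain or a longer decyl chain would do as well. From the compounds shown here alone, it is also open whether the chain must be plain carbon, or whether an amine or a carboxylic acid at its end would keep the effect.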